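The compounds below may be only part of what the source reports. "The series", "measured", "known", "first", "only" and "open" are said of these compounds alone.

Of the compounds shown here, three that share one core have been measured in a functional assay on MGC-803 cells (Homo sapiens) for antiproliferative activity, read by MTT assay, with a stated time of 72 h; on this read-out higher numbers stand for weaker inhibition and lower numbers for stronger inhibition. Compound 1 `CCCSc1nc(N/N=C/c2cccnc2)c2nnn(Cc3ccccc3)c2n1` gives 38100 nM. Compound 2 `CCCSc1nc(N/N=C/c2ccc(Br)cc2)c2nnn(Cc3ccccc3)c2n1` gives 34900 nM, and the step of a 1.1-fold lower number from compound 1 to compound 2 (0.04 log units; within the scatter) stays within the scatter, so the two cannot be ranked. Compound 3 `CCCSc1nc(N/N=C/c2ccccc2)c2nnn(Cc3ccccc3)c2n1` reaches only the limit > 64000 nM in this assay, so no number is known for it. Where it stands is fixed only by the limit of > 64000 nM in this assay, at which 1 of the 3 values shown sits. Compound 4 `CCCSc1nc(N/N=C/c2ccc([N+](=O)[O-])cc2)c2nnn(Cc3ccccc3)c2n1` has not yet been measured. It differs from compound 3 by nitro in place of hydrogen on an aromatic carbon. For the measured compounds named here, the measured step that bears on this change is the one in which a group leaves the same aromatic carbon, an at least 1.8-fold higher number from compound 2 to compound 3 (0.26 log units; that floor lies within the scatter), whose floor lies within the scatter but points toward a higher number once the carbon carries only hydrogen. Adding nitro is therefore expected to move the number the other way, giving a step of about an at least 1.8-fold lower number from compound 3 to compound 4 (0.26 log units; that floor lies within the scatter). Compound 4 is thus estimated at 35000 nM, with a range from 15000 nM to 80000 nM, while the assay might again report only its limit.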

Compound 4, half-maximal inhibitory concentration: 10100 nM
Compound 4: the middle estimate sits 3.5-fold (0.54 log units) above what was measured; measured number outside the range, below it.
By their numbers in this assay, from the lowest: compound 4; then compounds 2 and 1 (each within the scatter of the next). At a limit, above all of these: compound 3.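

In this assay, the carbon para to a large group now shows a step beyond the scatter: nitro in place of hydrogen gives an at least 6.3-fold lower number from compound 3 to compound 4 (0.80 log units; beyond the scatter), and that size is only a floor, as compound 3 has a limit and not a number. Nitro also separates from bromo on the same carbon, with a 3.5-fold lower number from compound 2 to compound 4 (0.54 log units; beyond the scatter), so the identity of the group matters here and not merely the presence of one. The 4-nitrophenyl also stands apart from pyridin-3-yl, with a 3.8-fold lower number from compound 1 to compound 4 (0.58 log units; beyond the scatter), which gives compound 4 the lowest number of the four compounds.

As far as these compounds go, with only bromo and nitro on this carbon, it remains open how an amine, a methoxy group or a carboxylic acid there would read. From the compounds shown here alone, it is also open whether nitro would produce a similar step if a longer chain replaced the propyl chain on sulfur.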